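A few compounds are considered here, and "the series" means these few. Any claim that something is new, unique, unknown or untested is made for them only; others in the source may bear on it.

Working notes on the series. Compound 1 `CN(C)C(=O)C1CCN(c2nc(-c3cc(F)c(Cl)cc3F)nc3c2CS(=O)(=O)C3)CC1` carries a dimethylcarbamoyl group on the saturated ring; in a functional assay on the whole organism (blood, strain ICR) with Mus musculus as the target, in the glucose tolerance test, with a stated time of 30 min (a higher number here means that more compound is needed for the effect, a lower number that less compound is needed), compound 1 gives 1 mg/kg. Going by the values given here, compound 2 `O=S1(=O)Cc2nc(-c3cc(F)c(Cl)cc3F)nc(N3CCC(O)CC3)c2C1` is the only measured neighbour, and in this assay compound 2 gives 1 mg/kg. Among the compounds with values here, the one step measured so far is no change at the digits printed from compound 1 to compound 2 (within the scatter), so compound 1 stands level with compound 2 and the two cannot be ordered on these numbers.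

Compound 3 `CNC(=O)C1CCN(c2nc(-c3cc(F)c(Cl)cc3F)nc3c2CS(=O)(=O)C3)CC1` is the next member to be tested. The change from compound 1 is hydrogen in place of methyl on an amide-type nitrogen. Within the data shown here, no measured step touches the amide nitrogen itself; the only step that bears on this end of the molecule is the exchange of the whole dimethylcarbamoyl for hydroxy, which left the read-out unchanged, and that is a larger change than a single methyl leaving. The expectation is therefore a step of about no change at the digits printed from compound 1 to compound 3 (within the scatter), none beyond the scatter. Compound 3 is estimated at 1 mg/kg, with a range of 0.3 mg/kg to 3 mg/kg.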

Compound 3, minimum effective dose in the Mus musculus assay: 3 mg/kg
Estimate against measurement, compound 3: 3.0-fold (0.48 log units) below, within the range that was stated.
By their numbers in the Mus musculus assay, from the lowest: compounds 1 and 2 (each within the scatter of the next); then compound 3.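

Removing one methyl from the amide-type nitrogen shifts the read-out where the larger exchange for hydroxy had not: in the Mus musculus assay the change is a 3.0-fold higher number from compound 1 to compound 3 (0.48 log units; beyond the scatter), and the comparison with the hydroxy compound gives a 3.0-fold higher number from compound 2 to compound 3 (0.48 log units; beyond the scatter). In a physicochemical assay for solubility, with a stated time of 20 h, at pH 6.8 (on this read-out lower numbers stand for lower solubility and higher numbers for higher solubility), compound 1 gives > 100000 nM, which is a limit of the assay and not a number. In the physicochemical assay compound 3 gives 11000 nM, and the step, an at least 9.0-fold lower number from compound 1 to compound 3 (0.95 log units; beyond the scatter), therefore gives only a minimum for the size of the change: the limit of > 100000 nM in the physicochemical assay, at which 1 of the 2 values shown sits.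

As far as these compounds go, it remains open how an ethyl group or a longer chain on the amide nitrogen, or a carboxylic acid in place of the amide, would read in either assay. From the compounds shown here alone, with a single step at this nitrogen, it also remains open whether the two read-outs move together across the series.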